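The compounds below may be only part of what the source reports. "The series", "measured", "known", "first", "only" and "open" are said of these compounds alone.

Measured in a functional assay on HCT-15 cells (Homo sapiens) for cytotoxicity, in the presence of a further agent that is not named here; a higher number here means a weaker inhibitor, a lower number a stronger inhibitor:
- compound 1 `Cc1ccc(-c2cc(-c3ccc(Cl)o3)cc(-c3ccsc3)n2)o1`: > 50000 nM (a limit)
- compound 2 `Cc1ccc(-c2cc(-c3ccc(Cl)o3)cc(-c3cccs3)n2)cc1`: 9890 nM

Among the measured compounds shown here, compound 2, at 9890 nM, holds the only actual number in this assay. Compound 1 gives > 50000 nM, which is a limit of the assay.

Compound 3 `Cc1ccc(-c2cc(-c3ccc(Cl)o3)cc(-c3ccsc3)n2)cc1` has the same atoms as compound 2, with thiophen-3-yl in place of thiophen-2-yl on an aromatic carbon. For the measured compounds named here, no measured pair isolates this change, so only a modest effect is expected. The expected step is a 1.1-fold higher number from compound 2 to compound 3 (0.05 log units; within the scatter), none beyond the scatter and with no clear direction. For compound 3 the estimated value is 11000 nM, with an expected range of 4000 nM to 32000 nM.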

Compound 3, half-maximal inhibitory concentration: 7410 nM
Beside the measured number, compound 3's estimate is 1.5-fold (0.17 log units) above it, within the range that was stated.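

Swapping thiophen-2-yl for thiophen-3-yl on the aromatic carbon next to the ring nitrogen makes no readable difference in this assay: a 1.3-fold lower number from compound 2 to compound 3 (0.13 log units; within the scatter). With thiophen-3-yl held, 4-methylphenyl in place of 5-methylfuran-2-yl gives an at least 6.7-fold lower number from compound 1 to compound 3 (0.82 log units; beyond the scatter), so in this pair the change at that other place on the shared core separates the compounds. The entry for compound 1 is a limit, not a number: the limit of > 50000 nM in this assay, at which 1 of the 3 values shown sits.

Still open, going by these compounds, is whether an amine or a carboxylic acid in place of the thiophene keeps the activity seen here. On these data alone, the contribution of the 5-chlorofuran-2-yl group also remains open.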